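Methyl for chloro on a shared anilino group

The source may report more compounds than this note shows. Statements on the series, on what has been measured and on what is new or still open speak of the compounds shown alone.

Of the compounds shown here, three have been measured in an assay on Sf9 cells for inhibition of 1-acyl-sn-glycerol-3-phosphate acyltransferase beta (Homo sapiens); a higher number here means a weaker inhibitor, a lower number a stronger inhibitor. Compound 1 `COc1ccc(Cl)cc1-c1cc(N)cc(Nc2ccc(Cl)cc2)n1` gives 6500 nM. Compound 2 `COc1ccc(Cl)cc1-c1cc(N)cc(Nc2ccc(C)cc2)n1` gives 29000 nM. The two differ by methyl in place of chloro on an aromatic carbon and the step is a 4.5-fold higher number from compound 1 to compound 2 (0.65 log units; beyond the scatter). Compound 3 `CCOc1ccc(Cl)cc1-c1cc(N)nc(Nc2ccc(Cl)cc2)c1` gives 50 nM, the lowest number of the three; the difference between its core and that of compound 1 is not broken down here.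

Compound 4 `CCOc1ccc(Cl)cc1-c1cc(N)nc(Nc2ccc(C)cc2)c1` is not yet measured. It differs from compound 3 by methyl in place of chloro on an aromatic carbon, the same change seen from compound 1 to compound 2. Because the earlier step was a 4.5-fold higher number from compound 1 to compound 2 (0.65 log units; beyond the scatter), a step of similar size, a 4.4-fold higher number from compound 3 to compound 4 (0.64 log units; beyond the scatter), is expected here, though the core is different and the match is uncertain. Compound 4 is therefore estimated at 220 nM, between 80 nM and 700 nM.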

Compound 4, half-maximal inhibitory concentration: 490 nM
Compound 4: middle estimate off by 2.2-fold (0.35 log units), on the low side; the measured number falls inside the stated range.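

In this assay, the change from 4-chlorophenyl to 4-methylphenyl gives a 9.8-fold higher number from compound 3 to compound 4 (0.99 log units; beyond the scatter). Set beside the earlier step, the change raises the number on both cores, and the gap between the two sizes is no larger than repeated measurements could produce: the same change on two cores in this assay, a 4.5-fold higher number (0.65 log units; beyond the scatter) from compound 1 to compound 2 and a 9.8-fold higher number (0.99 log units; beyond the scatter) from compound 3 to compound 4, 2.2-fold (0.34 log units) apart, within the scatter of two such steps. The change therefore carried over between these two cores, but two pairs do not show that it would carry to any other core, and they do not explain why chloro gives the lower number.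

Going by these compounds, it remains open how a nitrile or a carboxylic acid in the same place would compare with chloro and methyl. Also open, on these data alone, is how much each structural difference between the cores of compound 1 and compound 3 contributes to the gap between their values.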